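The source may report more compounds than this note shows. Statements on the series, on what has been measured and on what is new or still open speak of the compounds shown alone.

Measured so far in a physicochemical assay for lipophilicity; a lower number here means a more polar compound, a higher number a more lipophilic compound:
- compound 1 `CCOC(=O)c1ccc(S(N)(=O)=O)cc1` gives 1.17
- compound 2 `CCCCOC(=O)c1ccc(S(N)(=O)=O)cc1` gives 2.34
- compound 3 `CCCCCCOC(=O)c1ccc(S(N)(=O)=O)cc1` gives 3.23

Compound 2 is second highest of the three in this assay with the step of a number 0.89 log units higher from compound 2 to compound 3 (beyond the scatter) above it and the step of a number 1.17 log units higher from compound 1 to compound 2 (beyond the scatter) below it.

Compound 4 `CCNC(=O)c1ccc(S(N)(=O)=O)cc1` has not yet been measured. It carries ethylamino in place of butoxy on a carbonyl carbon. Two things therefore change at once. The chain becomes shorter, and the closest guide to this is a number 1.17 log units higher from compound 1 to compound 2 (beyond the scatter) read in reverse, which is a large step. The step of a number 2.06 log units higher from compound 1 to compound 3 (beyond the scatter) is also large, and together with the other two steps it shows the number rising with chain length across these three compounds. Among the compounds with values here, no measured pair shows the other change, from an oxygen to a nitrogen on the carbonyl carbon, so that part of the estimate is a judgement and the range is kept wide. The estimate allows for a further fall beyond the chain step alone. The expected change is a large fall, beyond the scatter, estimated as a number 2.14 log units lower from compound 2 to compound 4 (beyond the scatter) in all. Compound 4 is expected at 0.2 (estimated range -0.3 to 0.7).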

Compound 4, partition coefficient: 0.03
For compound 4 the middle estimate is 0.17 log units above the measured one; the range from low to high includes it.
By their numbers in this assay, from the lowest: compound 4; then compound 1; then compound 2; then compound 3.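

In this assay, within the data shown here, compound 4 keeps the ethyl chain of compound 1, so the step of a number 1.14 log units lower from compound 1 to compound 4 (beyond the scatter) shows for the first time what the change from oxygen to nitrogen on the carbonyl carbon does with the chain length unchanged, and that step is large. The fall of a number 2.31 log units lower from compound 2 to compound 4 (beyond the scatter) holds two changes at once, a shorter chain and the change from oxygen to nitrogen on the carbonyl carbon, and the chain part matches a number 1.17 log units higher from compound 1 to compound 2 (beyond the scatter) read in reverse, so both parts of the fall are large and the change of atom matters at this position as well as the chain length. Nothing measured here explains why this change of atom lowers the number.

The compounds shown leave open whether a longer chain on the nitrogen, such as butylamino or hexylamino, would raise the number as butoxy and hexyloxy do in place of ethoxy. They also leave open whether dimethylamino, which carries no amide hydrogen, would give a fall of the same size as ethylamino.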